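Acylguanidine series: amino in place of imidazolyl

This account rests on a few compounds, and the source may have more. Where it says the series, first, only, none or still open, it means among the compounds named here.

Measured in a functional assay for inhibition of sodium/hydrogen exchanger (Oryctolagus cuniculus); on this read-out higher numbers stand for weaker inhibition and lower numbers for stronger inhibition:
- compound 1 `Cc1cc(Br)c(S(C)(=O)=O)cc1C(=O)N=C(N)N`: 12 nM
- compound 2 `Cc1cc(-n2ccnc2C)c(S(C)(=O)=O)cc1C(=O)N=C(N)N`: 29 nM

Within the data shown here, compound 2 stands at the highest of the two numbers; its only neighbour is compound 1, and the step of a 2.4-fold higher number from compound 1 to compound 2 (0.38 log units; beyond the scatter) lies beyond the scatter. Compound 3 `Cc1cc(N)c(S(C)(=O)=O)cc1C(=O)N=C(N)N` is not yet measured; it differs from compound 2 by amino in place of 2-methyl-1H-imidazol-1-yl on an aromatic carbon.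

Among the measured compounds shown here, only one measured step bears on this change, and only in part: a 2.4-fold higher number from compound 1 to compound 2 (0.38 log units; beyond the scatter) shows what the 2-methyl-1H-imidazol-1-yl group did when it replaced bromo. For the measured compounds named here, no step with an amino group at this carbon exists. Removing the imidazolyl again is therefore expected to undo most of that modest rise, and compound 3 is estimated to sit near compound 1, which gives 12 nM, with a step of a 1.9-fold lower number from compound 2 to compound 3 (0.29 log units; within the scatter) expected. The estimate for compound 3 in this assay is 15 nM, within 6 nM to 40 nM.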

Compound 3, half-maximal inhibitory concentration: 16 nM
Compound 3: middle estimate off by 1.1-fold (0.03 log units), on the low side; low and high end bracket the measured number.
By their numbers in this assay, from the lowest: compounds 1, 3 and 2 (each within the scatter of the next, the first and the last beyond it).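

In this assay, amino on this aromatic carbon, ortho to a methylsulfonyl group, gives a 1.8-fold lower number from compound 2 to compound 3 (0.26 log units; within the scatter) and a 1.3-fold higher number from compound 1 to compound 3 (0.12 log units; within the scatter), so compound 3 cannot be separated from either neighbour. The position therefore accommodates a group of 1 heavy atom with a hydrogen-bond donor as well as 2-methyl-1H-imidazol-1-yl with its 6 heavy atoms and five-membered aromatic ring, and the only difference beyond the scatter remains that between compound 1 and compound 2. Nothing available explains this narrow spread of numbers.

Going by these compounds, whether a dimethylamino group, a carboxylic acid or a longer chain on this carbon would stay within the same narrow range remains open. Also open, on these data alone, is whether the tolerance seen with these three groups would hold if the methyl or methylsulfonyl group of the shared core were changed.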